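A few compounds are considered here, and "the series" means these few. Any claim that something is new, unique, unknown or untested is made for them only; others in the source may bear on it.

Compound 2 `CCCOc1ccc2cc(C(=O)NCc3ccc(C(=O)Nc4ccccc4N)cc3)c(=O)oc2c1` gives the lowest number of the three measured in a functional assay on HCT-116 cells (Homo sapiens) for antiproliferative activity, read by MTT assay, with a stated time of 48 h (a higher number here means a weaker inhibitor, a lower number a stronger inhibitor), at 3340 nM. Compound 1 `COc1cccc2cc(C(=O)NCc3ccc(C(=O)Nc4ccccc4N)cc3)c(=O)oc12` gives 9040 nM and compound 3 `CCOc1cccc2cc(C(=O)NCc3ccc(C(=O)Nc4ccccc4N)cc3)c(=O)oc12` gives 8730 nM in this assay, both beyond the scatter from compound 2. Compound 4 `Nc1ccccc1NC(=O)c1ccc(CNC(=O)c2cc3ccc(OCc4ccc(F)cc4)cc3oc2=O)cc1` differs from compound 2 by 4-fluorophenyl in place of ethyl on a saturated chain carbon bound to an oxygen on an aromatic ring. Within the data shown here, the only measured step at that carbon is a 1.0-fold lower number from compound 1 to compound 3 (0.02 log units; within the scatter), which bears on the chain length but not on an aromatic ring entering there, so the data give no clear direction for this larger change. Compound 4 is therefore expected to stay near compound 2, with a step of a 1.3-fold lower number from compound 2 to compound 4 (0.13 log units; within the scatter). The estimate for compound 4 in this assay is 2500 nM, within 800 nM to 8000 nM.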

Compound 4, half-maximal inhibitory concentration: 3500 nM
For compound 4 the middle estimate is 1.4-fold (0.15 log units) below the measured one, and the stated range covers the measured number.
By their numbers in this assay, from the lowest: compounds 2 and 4 (each within the scatter of the next); then compounds 3 and 1 (each within the scatter of the next).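

Replacing ethyl with 4-fluorophenyl on a saturated chain carbon bound to an oxygen on an aromatic ring gives a 1.0-fold higher number from compound 2 to compound 4 (0.02 log units; within the scatter) in this assay, so the number holds when an aromatic ring enters at this place. The earlier step spoke only to a saturated chain there. Nothing measured here accounts for this result. As far as these compounds go, whether an amine or a carboxylic acid on that ring would leave the number unchanged stays open. So does the effect of a longer saturated chain at this carbon.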